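Nitro substitution in a benzyloxy aniline series

The source may report more compounds than this note shows. Statements on the series, on what has been measured and on what is new or still open speak of the compounds shown alone.

Compound 1, `c1ccc(COc2ccccc2Nc2ncnc3cc4c(cc23)OCCOCCO4)cc1`: in a functional assay on DU-145 cells (Homo sapiens) for antiproliferative activity, read by MTT assay, with a stated time of 72 h (on this read-out lower numbers stand for stronger inhibition and higher numbers for weaker inhibition), compound 1 reaches only the limit of the assay, > 100000 nM.
Compound 2, `O=[N+]([O-])c1ccc(COc2ccccc2Nc2ncnc3cc4c(cc23)OCCOCCO4)cc1`: in this assay compound 2 gives 85600 nM.
Compound 3, `c1ccc(COc2cccc(Nc3ncnc4cc5c(cc34)OCCOCCOCCO5)c2)cc1`: in this assay compound 3 reaches only the limit of the assay, > 100000 nM.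

Compound 1 and compound 2 differ by nitro in place of hydrogen on an aromatic carbon. The resulting step, an at least 1.1-fold lower number from compound 1 to compound 2 (0.06 log units; that floor lies within the scatter), is read against (the limit of > 100000 nM in this assay, at which 2 of the 3 values shown sit). The difference between the core of compound 3 and the core of compound 1 is not broken down here. Compound 4, `O=[N+]([O-])c1ccc(COc2cccc(Nc3ncnc4cc5c(cc34)OCCOCCOCCO5)c2)cc1`, is not yet measured and differs from compound 3 by nitro in place of hydrogen on an aromatic carbon, the same change as before. For compound 4 the expected value in this assay is 90000 nM, most likely between 40000 nM and 200000 nM. This estimate rests on compound 3 sitting at the limit > 100000 nM. It also rests on the small earlier step of an at least 1.1-fold lower number from compound 1 to compound 2 (0.06 log units; that floor lies within the scatter). The step this estimate means, an at least 1.1-fold lower number from compound 3 to compound 4 (0.04 log units; that floor lies within the scatter), is expected to stay within the scatter, and a limit may well be reported again.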

Compound 4, half-maximal inhibitory concentration: > 100000 nM
Compound 4: no number, only a limit (the forecaster's own chance of this, stated with the estimate: 50%); middle value at least 1.1-fold (0.04 log units) from the limit.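

Compound 3 and compound 4 both give only a limit in this assay, so no step can be read between them: the limit of > 100000 nM in this assay, at which 3 of the 4 values shown sit.

On these data alone, whether nitro in place of hydrogen changes anything on the core of compound 3 remains open.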